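The compounds below may be only part of what the source reports. "The series", "measured", "known", "first", "only" and "open" are said of these compounds alone.

Working notes on the series.

Of the compounds shown here, two have numbers so far. Compound 1 `COCC(C)(C)Nc1nc(C)nc2c1nnn2-c1ccc(C(C)C)cc1Br` gives 195 nM in an in vitro assay on 293-EBNA cells for binding affinity to corticotropin-releasing factor receptor 1 (Homo sapiens); a higher number here means a weaker inhibitor, a lower number a stronger inhibitor. Compound 2 `CCCCN(CC)c1nc(C)nc2c1nnn2-c1c(Cl)cc(OC)cc1OC` gives 4.4 nM in this assay. Compound 1 thus stands with the highest of the two numbers, and compound 2 has the lower one; the two differ in more than one place, so nothing beyond the two values themselves is to be drawn from the pair.

Compound 3 `COCC(COC)Oc1nc(C)nc2c1nnn2-c1ccc(C(C)C)cc1Br` is not yet measured. It differs from compound 1 as follows: a group of 8 heavy atoms (5 carbon, 3 oxygen; no ring) in place of a group of 7 heavy atoms (5 carbon, 1 nitrogen, 1 oxygen; no ring), on an aromatic carbon. The group that leaves carries the one hydrogen-bond donor of that part of the molecule; the group that enters has none, and one more hydrogen-bond acceptor. The place is on an aromatic carbon of the shared core, next to the ring nitrogen.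

Among the measured compounds shown here, no measured step of this kind is at hand. With the donor gone and compound 1 already giving 195 nM, a modest move toward a higher number is expected, close to the scatter, as a 1.8-fold higher number from compound 1 to compound 3 (0.25 log units; within the scatter). Compound 3 is estimated at 350 nM, within 70 nM to 1800 nM.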

Compound 3, inhibition constant: 7.1 nM
Compound 3: middle estimate off by 49-fold (1.69 log units), on the high side; measured number outside the range, below it.
By their numbers in this assay, from the lowest: compounds 2 and 3 (each within the scatter of the next); then compound 1.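

In this assay, the aromatic carbon next to the ring nitrogen proves highly sensitive to what it carries: replacing the (1-(methoxymethyl)-1-methylethyl)amino group with the group of 8 heavy atoms gives a 27-fold lower number from compound 1 to compound 3 (1.44 log units; beyond the scatter), while the rest of the molecule stays the same. The earlier pair could not show this, as its two compounds differ in more than one place; this step isolates a single position and shows that, at least in this pair, the hydrogen-bond donor of the leaving group is not needed for a low number. No measurement is available that explains the size of this step.

The change removes the donor, adds an acceptor and alters the group's carbon framework all at once, so these contributions remain unseparated; an amine carrying the same two methoxymethyl arms, or a simple methoxy group at this position, would bear on that question. Also open, as far as these compounds go, is whether a step of this size would recur with the remainder of compound 2 in place of the remainder of compound 1.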